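Dithioester variants of a bromoanilino enaminone: working notes

This account rests on a few compounds, and the source may have more. Where it says the series, first, only, none or still open, it means among the compounds named here.

Compound 1 `CC1(C)CC(=O)C=C(Nc2ccc(Br)cc2)C1`; in a functional assay on PBMC cells (Homo sapiens) for inhibition, read by ELISA, with a stated time of 18 h (on this read-out lower numbers stand for stronger inhibition and higher numbers for weaker inhibition), compound 1 gives > 20 ug/mL, a limit of the assay.
Compound 2 `CCCCSC(=S)C1=C(Nc2ccc(Br)cc2)CC(C)(C)CC1=O`; in this assay compound 2 gives > 20 ug/mL, again a limit.
Compound 3 `CCCCCCCCCCCSC(=S)C1=C(Nc2ccc(Br)cc2)CC(C)(C)CC1=O`; in this assay compound 3 gives > 20 ug/mL, also a limit.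

Compound 3 thus stands at the limit of this assay, together with the two other measured compounds, as the limit of > 20 ug/mL in this assay, at which 3 of the 3 values shown sit, shows. Neither step among the measured compounds can be read: a step that the two limits leave unreadable from compound 1 to compound 2, and a step that the two limits leave unreadable from compound 2 to compound 3. Both steps change the dithioester chain, and both end at the limit, so they carry no readable size.

Compound 4 `CC1(C)CC(=O)C(C(=S)SCCO)=C(Nc2ccc(Br)cc2)C1` differs from compound 3 by hydroxy in place of nonyl on a saturated chain carbon, two bonds along the chain from a sulfur. Among the measured compounds shown here, the two unreadable steps on the same chain are the only evidence that bears on this change, and they give no direction. The expected step is therefore a step that the limit leaves unreadable from compound 3 to compound 4, with most of the weight on a further limit. For compound 4 the estimate in this assay is 30 ug/mL, in the range 8 ug/mL to 120 ug/mL.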

Compound 4, half-maximal inhibitory concentration: > 20 ug/mL
Compound 4 was reported as a limit; the forecaster's own chance of this, stated with the estimate: 80%; the middle value does not contradict the limit.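

No step from compound 1, compound 2 or compound 3 to compound 4 can be read in this assay, as all four values are limits: the limit of > 20 ug/mL in this assay, at which 4 of the 4 values shown sit.

The compounds shown leave open whether any change to the dithioester chain, hydroxy included, alters inhibition in this assay.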